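This account rests on a few compounds, and the source may have more. Where it says the series, first, only, none or still open, it means among the compounds named here.

Compound 1 `NC(=O)CCCC/C=C(\c1ccccc1)c1cccnc1` gives 400 nM in an assay (Equus caballus) for inhibition of Thromboxane-A synthase (Homo sapiens), using microsomes; on this read-out higher numbers stand for weaker inhibition and lower numbers for stronger inhibition.
Compound 2 `CSC(CCC/C=C(\c1ccccc1)c1cccnc1)C(=O)O` gives 30 nM in this assay.
Compound 3 `CC(C)(CCC/C=C(\c1ccccc1)c1cccnc1)C(=O)O` gives 21 nM in this assay.

Compound 3 has the lowest of the three numbers, but its gap to compound 2 is within the scatter, so the two cannot be told apart; only compound 1 stands clearly higher. Compound 4 `CC(C)(O)C(CCC/C=C(\c1ccccc1)c1cccnc1)C(=O)O` has not yet been measured. It differs from compound 3 in one place: 1-carboxy-2-hydroxy-2-methylpropyl in place of 1-carboxy-1-methylethyl on a saturated chain carbon, three bonds along the chain from a double-bonded chain carbon.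

Two measured steps speak to this region of the molecule. The change from the amide of compound 1 to a carboxy-bearing group gave large drops, a 13-fold lower number from compound 1 to compound 2 (1.12 log units; beyond the scatter) and a 19-fold lower number from compound 1 to compound 3 (1.28 log units; beyond the scatter). Exchanging one carboxy-bearing group for another gave a 1.4-fold lower number from compound 2 to compound 3 (0.15 log units; within the scatter). Within the data shown here, compound 4 keeps the carboxy group and adds a hydroxy and a methyl; no measured step tests such an addition on its own. Since the swap between carboxy-bearing groups stayed within the scatter, the expected step for compound 4 is a 1.4-fold higher number from compound 3 to compound 4 (0.15 log units; within the scatter), with no clear direction beyond the scatter. Compound 4 is therefore estimated at 30 nM in this assay, within 8 nM to 110 nM.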

Compound 4, half-maximal inhibitory concentration: 42 nM
Estimate against measurement, compound 4: 1.4-fold (0.15 log units) below; the range from low to high includes it.
By their numbers in this assay, from the lowest: compounds 3, 2 and 4 (each within the scatter of the next); then compound 1.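

In this assay, this position takes the 1-carboxy-2-hydroxy-2-methylpropyl group, with 8 heavy atoms in place of the 6 of 1-carboxy-1-methylethyl, without a step beyond the scatter (a 2.0-fold higher number from compound 3 to compound 4 (0.30 log units; within the scatter)). Putting 1-hydroxy-1-methylethyl in place of methylsulfanyl also stays within the scatter (a 1.4-fold higher number from compound 2 to compound 4 (0.15 log units; within the scatter)), so these three carboxy-bearing groups cannot be told apart here, while compound 4 still stands clearly apart from the amide (a 9.5-fold lower number from compound 1 to compound 4 (0.98 log units; beyond the scatter)); all three carboxy-bearing compounds now share that separation from compound 1, and none of the compounds shown goes against it. No separate measurement is available to explain these numbers.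

The compounds shown do not separate the added hydroxy from the added carbon, since compound 4 brings both in one step, so the contribution of each remains unknown. Also open, on these data alone, is how the number would respond to an amine in place of the hydroxy, to a methyl ester in place of the carboxylic acid, or to a longer chain carrying the carboxylic acid.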